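This account rests on a few compounds, and the source may have more. Where it says the series, first, only, none or still open, it means among the compounds named here.

Measured in a functional assay on MDA-MB-231 cells (Homo sapiens) for antiproliferative activity, read by MTT assay, with a stated time of 48 h; on this read-out higher numbers stand for weaker inhibition and lower numbers for stronger inhibition:
- Compound 1 `C=CS(=O)(=O)N1CCN(c2ncnc3sc(-c4ccnc(Cl)c4)cc23)CC1`: 27700 nM
- Compound 2 `C=CS(=O)(=O)N1CCN(c2ncnc3sc(-c4c(C)noc4C)cc23)CC1`: 28200 nM

On these two numbers, compound 2 stands level with compound 1, with no difference beyond the scatter of repeated measurements. Compound 3 `C=CS(=O)(=O)N1CCN(c2ncnc3sc(-c4cccs4)cc23)CC1` has not yet been measured. It carries thiophen-2-yl in place of 3,5-dimethyl-1,2-oxazol-4-yl on an aromatic carbon, next to the ring sulfur: thiophen-2-yl in place of 3,5-dimethyl-1,2-oxazol-4-yl on an aromatic carbon.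

Going by the values given here, only one measured step bears on this change, since it too replaces one aromatic group with another: a 1.0-fold higher number from compound 1 to compound 2 (0.01 log units; within the scatter). A single step is thin evidence, but it gives no reason to predict a large shift in this assay. The expected step is a 1.2-fold lower number from compound 2 to compound 3 (0.07 log units; within the scatter), which would not exceed the scatter. For compound 3 the estimated value is 24000 nM, with an expected range from 10000 nM to 50000 nM.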

Compound 3, half-maximal inhibitory concentration: 34100 nM
Compound 3: middle estimate off by 1.4-fold (0.15 log units), on the low side; the range from low to high includes it.
By their numbers in this assay, from the lowest: compounds 1, 2 and 3 (each within the scatter of the next).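

In this assay, thiophen-2-yl gives a 1.2-fold higher number from compound 2 to compound 3 (0.08 log units; within the scatter), and measured against the 2-chloropyridin-4-yl group it gives a 1.2-fold higher number from compound 1 to compound 3 (0.09 log units; within the scatter). Thiophen-2-yl has fewer heavy atoms and fewer hydrogen-bond acceptors than 3,5-dimethyl-1,2-oxazol-4-yl, yet this difference is not matched by any step beyond the scatter, so this assay does not separate the three aromatic groups tried on this carbon. No measurement shown here accounts for why the three compounds read alike.

On these data alone, all three groups are aromatic rings, so it remains open whether a group of another kind at this place, such as an amine, a carboxylic acid or a longer chain, would give a different number. As far as these compounds go, it also remains open whether any change at this carbon can give a step beyond the scatter.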